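A few compounds are considered here, and "the series" means these few. Any claim that something is new, unique, unknown or untested is made for them only; others in the source may bear on it.

Compound 1 `c1ccc(Cn2nnc3c(NC4CCCCC4)ncnc32)cc1` carries a cyclohexyl group on the nitrogen attached to its core, and in an assay on cell membranes for binding affinity to adenosine receptor A1 (Bos taurus), read by radioligand binding (on this read-out higher numbers stand for weaker inhibition and lower numbers for stronger inhibition), compound 1 gives 121 nM. Among the three numbers shown it stands second highest: compound 2 `Cc1ccc(Nc2ncnc3c2nnn3Cc2ccccc2Cl)cc1` gives 119 nM, which lies within the scatter of compound 1, while compound 3 `Cc1cccc(Nc2ncnc3c2nnn3Cc2ccccc2Cl)c1` gives 5880 nM, far higher. Compounds 2 and 3 differ only in where the methyl sits on the phenyl ring, and that move alone produced a 49-fold higher number from compound 2 to compound 3 (1.69 log units; beyond the scatter).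

Compound 4 `Clc1cccc(Nc2ncnc3c2nnn3Cc2ccccc2)c1` has not yet been measured in this assay. It differs from compound 1 by 3-chlorophenyl in place of cyclohexyl on a nitrogen on an aromatic ring. For the measured compounds named here, no measured step swaps cyclohexyl for a phenyl ring, but compound 2, with a 4-methylphenyl on the same nitrogen, sits close to compound 1, whereas compound 3, with its 3-methylphenyl, sits far higher. Since compound 4 bears its chlorine in that 3-position, a sizeable rise is expected, roughly a 17-fold higher number from compound 1 to compound 4 (1.22 log units; beyond the scatter). For compound 4 the estimated value in this assay is 2000 nM, with a plausible range from 400 nM to 10000 nM.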

Compound 4, inhibition constant: 463 nM
For compound 4 the middle estimate is 4.3-fold (0.64 log units) above the measured one; the measured number falls inside the stated range.
By their numbers in this assay, from the lowest: compounds 2 and 1 (each within the scatter of the next); then compound 4; then compound 3.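

In this assay, replacing the non-aromatic cyclohexyl with the aromatic 3-chlorophenyl gives a 3.8-fold higher number from compound 1 to compound 4 (0.58 log units; beyond the scatter). The earlier step only moved a methyl around a phenyl ring that was already on this nitrogen, whereas this one changes the kind of ring on it, from one of carbon only and non-aromatic to an aromatic one bearing a chlorine. The shift is real but modest, so compound 4 still binds measurably with this aromatic group in place of cyclohexyl, and nothing available explains the size of the shift.

For the compounds shown here, the single step brings in aromaticity and a chlorine together, so the share of each in the change stays open. A plain phenyl group on the same nitrogen would separate the two, and an open-chain hexyl group would test whether a ring is needed there at all.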